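Bromo to 3-carbamoylphenyl: expected microsomal clearance of compound 4

The compounds below may be only part of what the source reports. "The series", "measured", "known", "first", "only" and "open" are said of these compounds alone.

Compound 1 `Nc1ccc(S(=O)(=O)N2CCN(c3ncc(C(O)(C(F)(F)F)C(F)(F)F)cc3Br)CC2)cn1` was tested in an ADME assay (liver) for metabolic stability, with Liver microsome (Rattus norvegicus) as the target, using microsomes and NADPH, with a stated time of 30 min, tested at 1 uM (on this read-out higher numbers stand for fast clearance and lower numbers for slow clearance), where compound 1 gives 32 mL.min-1.g-1, the second highest of three numbers. Compound 2 `Nc1ccc(S(=O)(=O)N2CCN(c3ncc(C(O)(C(F)(F)F)C(F)(F)F)cc3C3CC3)CC2)cn1` gives 27 mL.min-1.g-1, and compound 3 `Nc1ccc(S(=O)(=O)N2CCN(c3ncc(C(O)(C(F)(F)F)C(F)(F)F)cc3C#CCO)CC2)cn1` gives 65 mL.min-1.g-1. The step of a 1.2-fold lower number from compound 1 to compound 2 (0.07 log units; within the scatter) stayed within the scatter, whereas a 2.0-fold higher number from compound 1 to compound 3 (0.31 log units; beyond the scatter) and a 2.4-fold higher number from compound 2 to compound 3 (0.38 log units; beyond the scatter) went beyond it. Compound 4 `NC(=O)c1cccc(-c2cc(C(O)(C(F)(F)F)C(F)(F)F)cnc2N2CCN(S(=O)(=O)c3ccc(N)nc3)CC2)c1` differs from compound 1 by 3-carbamoylphenyl in place of bromo on an aromatic carbon. The measured step from compound 1 to compound 3, which also replaced bromo with a group bearing a hydrogen-bond donor, is the closest guide, while the bromo-to-cyclopropyl step gave no shift; a rise of similar size is therefore expected for compound 4, a 1.7-fold higher number from compound 1 to compound 4 (0.24 log units; within the scatter). Compound 4 is estimated at 55 mL.min-1.g-1, with a range from 28 mL.min-1.g-1 to 110 mL.min-1.g-1.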

Compound 4, intrinsic clearance in microsomes: 63 mL.min-1.g-1
For compound 4 the middle estimate is 1.1-fold (0.06 log units) below the measured one; low and high end bracket the measured number.
By their numbers in this assay, from the lowest: compounds 2, 1, 4 and 3 (each within the scatter of the next, the first and the last beyond it).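

In this assay this position also accepts a much larger group bearing an aromatic ring: a 2.0-fold higher number from compound 1 to compound 4 (0.29 log units; within the scatter) stays within the scatter, while a 2.3-fold higher number from compound 2 to compound 4 (0.37 log units; beyond the scatter) goes beyond it. Two very different groups, 3-carbamoylphenyl and 3-hydroxyprop-1-yn-1-yl, cannot be told apart here, with a 1.0-fold lower number from compound 3 to compound 4 (0.01 log units; within the scatter) inside the scatter. No evidence is available on what sets the clearance of these compounds. Left open is whether a plain phenyl group, or a phenyl group carrying a carboxylic acid in place of the carbamoyl group, would give a number nearer that of compound 2.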